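Turning the pyridyl nitrogen: from compound 3 to compound 4

A few compounds are considered here, and "the series" means these few. Any claim that something is new, unique, unknown or untested is made for them only; others in the source may bear on it.

The study measures aryl-amino thiophene derivatives in a functional assay for inhibition, with a stated time of 2 h; on this read-out lower numbers stand for an effect already at smaller amounts and higher numbers for an effect only at larger amounts of compound. Compound 1 `COc1ccc(Nc2cccc3c(C)c(C)sc23)cc1` gives 8.45 ug/mL in this assay, and compound 2 `Cc1sc2c(Nc3ccc(C#N)cc3)cccc2c1C` gives 16 ug/mL. Within the data shown here, the one measured step, a 1.9-fold higher number from compound 1 to compound 2 (0.28 log units; within the scatter), is therefore of no real size. Among the measured compounds shown here, compound 3 `Cc1sc2c(Nc3ccccn3)cccc2c1C` stands apart: in this assay it gives only a limit of > 250 ug/mL, so no number is known for it, and it is the one value at the limit of > 250 ug/mL in this assay, at which 1 of the 3 values shown sits.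

Compound 4 `Cc1sc2c(Nc3cccnc3)cccc2c1C` differs from compound 3 in a single place: pyridin-3-yl in place of pyridin-2-yl on a nitrogen on an aromatic ring. For the measured compounds named here, no measured step concerns this change; the step between compound 1 and compound 2 alters a substituent on an aromatic carbon, not the aryl group on the nitrogen, and cannot be carried over. Going by the values given here, what is known is only that compound 1 and compound 2, carrying substituted phenyl groups, give numbers in this assay, whereas compound 3, carrying pyridin-2-yl, gives a limit. The expectation for compound 4 rests on that contrast alone: a value that may become measurable but is expected to remain high, with a real chance of a limit again. Compound 4 is estimated at 150 ug/mL, between 30 ug/mL and 250 ug/mL, an expected step of an at least 1.6-fold lower number from compound 3 to compound 4 (0.22 log units; that floor lies within the scatter) that cannot be sized against a limit.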

Compound 4, half-maximal effective concentration: 17.3 ug/mL
Compound 4: middle estimate off by 8.7-fold (0.94 log units), on the high side; the measured number lies below the stated range.
By their numbers in this assay, from the lowest: compounds 1, 2 and 4 (each within the scatter of the next, the first and the last beyond it). At a limit, above all of these: compound 3.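

In this assay, pyridin-3-yl in place of pyridin-2-yl on a nitrogen on an aromatic ring gives an at least 14-fold lower number from compound 3 to compound 4 (1.15 log units; beyond the scatter), a large change from a swap that leaves the heavy atoms, the hydrogen-bond donors and acceptors, and the net charge of the group as counted unchanged. The earlier compounds shown here could not show that a pyridyl group on this nitrogen is compatible with a measurable value, yet compound 2 gives 16 ug/mL and compound 4 gives 17.3 ug/mL, two values within the scatter of each other. The outcome at this position therefore depends on which pyridyl group is attached, and compound 3 is the only compound shown that stays at a limit of the assay: the limit of > 250 ug/mL in this assay, at which 1 of the 4 values shown sits.

The compounds shown leave open how pyridin-4-yl on the same nitrogen, or a methoxy group or an amine on the pyridin-3-yl ring, would read in this assay. The cause of the step also stays open, as the data shown hold no measurement that explains it.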